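Removing the phenethyl arm: a smaller pyridine acid

This account rests on a few compounds, and the source may have more. Where it says the series, first, only, none or still open, it means among the compounds named here.

Measured compounds:
compound 1, `O=C(O)CCCC/C=C(\c1cccnc1)c1cccc(Br)c1`, 180 nM
compound 2, `O=C(O)CCCC/C=C(\c1cccnc1)c1cccc(F)c1`, 55 nM
compound 3, `O=C(O)CCCC/C=C(/CCCc1ccccc1)c1cccnc1`, 65 nM

In an assay (Equus caballus) for inhibition of Thromboxane-A synthase (Homo sapiens), using microsomes (a higher number here means a weaker inhibitor, a lower number a stronger inhibitor), compound 3 gives 65 nM, the second highest of the three numbers. Compound 2 gives 55 nM, and the two values lie within the usual scatter of each other, so they cannot be told apart. Compound 1 gives 180 nM, a higher number than compound 3 and beyond the scatter, so compound 1 is the weaker inhibitor of that pair.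

Compound 4, `C/C(=C/CCCCC(=O)O)c1cccnc1`, is not yet measured. It differs from compound 3 in one place: hydrogen in place of phenethyl on a saturated chain carbon bound to a double-bonded chain carbon. This removes a whole aromatic ring and its two-carbon link, leaving only a methyl on that chain carbon.

Among the compounds with values here, the single measured step, a 3.3-fold lower number from compound 1 to compound 2 (0.51 log units; beyond the scatter), concerns an exchange of one halogen for another on a ring that compound 4 no longer carries, so it says little about this change. Within the data shown here, no measured pair shows what the phenethyl group contributes. Because compound 3 gives 65 nM with the arm in place, and the arm is a large part of the molecule, its loss is expected to weaken inhibition, that is, to raise the number in this assay beyond the scatter. The expected step is a 9.2-fold higher number from compound 3 to compound 4 (0.97 log units; beyond the scatter), with wide uncertainty. Compound 4 is estimated at 600 nM, with a range from 150 nM to 3000 nM.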

Compound 4, half-maximal inhibitory concentration: 71 nM
For compound 4 the middle estimate is 8.5-fold (0.93 log units) above the measured one, and the stated range ends above it.
By their numbers in this assay, from the lowest: compounds 2, 3 and 4 (each within the scatter of the next); then compound 1.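

In this assay the phenethyl arm on this chain carbon turns out not to be needed for inhibition: its loss leaves only a methyl on the double-bonded chain carbon, and the two compounds cannot be told apart (a 1.1-fold higher number from compound 3 to compound 4 (0.04 log units; within the scatter)). The same holds when the methyl stands in place of 3-fluorophenyl on that double-bonded carbon (a 1.3-fold higher number from compound 2 to compound 4 (0.11 log units; within the scatter)), so at this position a compound without any second aromatic ring matches those that carry one. Within the data shown here, only the exchange of 3-bromophenyl for methyl goes beyond the scatter (a 2.5-fold lower number from compound 1 to compound 4 (0.40 log units; beyond the scatter)), which makes 3-bromophenyl the one group of the three compared with methyl here that goes with a higher number.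

Nothing available explains why so large a change in size leaves the number within the scatter. Still open, as far as these compounds go, is whether a hydrogen or an ethyl group on the double-bonded carbon would behave like the methyl, and whether the small acid tolerates a shorter chain to its carboxylic acid or a phenyl ring in place of the pyridine.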